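Compound 2 to Compound 3: One Oxygen Function Changed

This account rests on a few compounds, and the source may have more. Where it says the series, first, only, none or still open, it means among the compounds named here.

In a functional assay on cells (Glioma cell, Mus musculus) for inhibition, with a stated time of 2 days, tested at 2 ug/mL (a higher number here means more inhibition at the concentration tested (going by the name of the read-out), a lower number less inhibition), compound 1 `C[C@H](O)[C@@H](O)/C=C/C=C/CC/C=C/C(=O)NCC(C)(C)O` gives 56%. Compound 2 `CC(O)/C=C/C=C/C(O)CC/C=C/C(=O)NCC(C)(C)O` gives 41% in this assay, the lower of the two numbers, standing beyond the scatter below compound 1. Compound 3 `CC(=O)/C=C/C=C/C(O)CC/C=C/C(=O)NCC(C)(C)O` has not been measured. It differs from compound 2 in one place: acetyl in place of 1-hydroxyethyl on a double-bonded chain carbon bound to a double-bonded chain carbon. Among the compounds with values here, no measured pair shows this change, so the account rests on the two numbers alone. A step of modest size, not clearly beyond the scatter in either direction, is expected, a number 4 percentage points higher from compound 2 to compound 3 (within the scatter). Compound 3 is therefore estimated at 45%, with a range from 25% to 65%.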

Compound 3, a percentage reported as inhibition, at one concentration (the size of the read-out at that concentration, not a potency): 52%
Compound 3: middle estimate off by 7 percentage points, on the low side; low and high end bracket the measured number.
By their numbers in this assay, from the lowest: compound 2; then compounds 3 and 1 (each within the scatter of the next).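

Acetyl in place of 1-hydroxyethyl on a double-bonded chain carbon bound to a double-bonded chain carbon gives a number 11 percentage points higher from compound 2 to compound 3 (beyond the scatter) in this assay and so gives the first sign that the read-out answers to this position. The 1-hydroxyethyl group is thus not needed here for inhibition at the concentration tested. Nothing at hand bears on why the step occurs.

Going by these compounds, whether an amine, a carboxylic acid or a longer chain at this place would raise or lower the number stays open. So does whether the same change would give a similar step on another compound.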